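This account rests on a few compounds, and the source may have more. Where it says the series, first, only, none or still open, it means among the compounds named here.

Measured compounds in an ADME assay on L02 cells (Homo sapiens) for antiproliferative activity, read by MTT assay, with a stated time of 48 h; on this read-out higher numbers stand for weaker inhibition and lower numbers for stronger inhibition:

compound 1 `COc1ccc(-n2nncc2CN2C(=O)C3(C(C#N)=C(N)Oc4c3c3nc5ccccc5nc3c3ccccc43)c3ccccc32)cc1` gives > 50000 nM, a limit of the assay, not a number.
compound 2 `N#CC1=C(N)Oc2c(c3nc4ccccc4nc3c3ccccc23)C12C(=O)N(Cc1cnnn1-c1cc(Cl)ccc1Cl)c1ccccc12` gives > 50000 nM, again a limit of the assay.
compound 3 `CCOc1ccc(-n2nncc2CN2C(=O)C3(C(C#N)=C(N)Oc4c(N)cc5nc6ccccc6nc5c43)c3ccccc32)cc1` gives > 50000 nM, once more a limit rather than a number.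

Compound 3 therefore stands nowhere within the readable range of this assay; it sits at the limit, and the other two values shown sit there with it (the limit of > 50000 nM in this assay, at which 3 of the 3 values shown sit). Among the compounds with values here, the only one-place step between measured compounds, a step that the two limits leave unreadable from compound 1 to compound 2, runs between two limits and its size cannot be read.

Compound 4 `N#CC1=C(N)Oc2c(N)cc3nc4ccccc4nc3c2C12C(=O)N(Cc1cnnn1-c1ccc(Cl)cc1[N+](=O)[O-])c1ccccc12` is the next member. Its change from compound 3 is 4-chloro-2-nitrophenyl in place of 4-ethoxyphenyl on an aromatic nitrogen. Within the data shown here, no measured step touches this change directly, and the one step that exists gives no readable size, so there is no measured basis for a shift in either direction in this assay beyond the scatter. With all three shown values at the limit, the expectation for compound 4 is that it stays at the limit as well, that is an expected step that the limit leaves unreadable from compound 3 to compound 4. The estimate for compound 4 in this assay is 80000 nM, expected to lie between 30000 nM and 300000 nM, most likely reported again only as a limit.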

Compound 4, half-maximal inhibitory concentration: > 50000 nM
Compound 4 was reported as a limit; the forecaster's own chance of this, stated with the estimate: 80%; the middle value is on the limit's open side.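

The change from compound 3 to compound 4 gives no readable step, and neither does any other pair shown, because every compound sits at a limit of this assay: the limit of > 50000 nM in this assay, at which 4 of the 4 values shown sit.

The compounds shown leave open whether any group on the aromatic nitrogen, or any difference in the core, shifts inhibition in this assay at all.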